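Dropping a Trifluoromethyl Group: Expected Shift in Lipophilicity

The source may report more compounds than this note shows. Statements on the series, on what has been measured and on what is new or still open speak of the compounds shown alone.

Measured compounds:
compound 1, `Cc1cc(N(C)C)ccc1-c1nnc(N(C)Cc2ccc3nccn3c2)o1`: 3.2
compound 2, `CNC(=O)c1sc(N2CC3CC2(CNC(=O)c2c[nH]c4ncc(C(F)(F)F)cc24)C3)nc1C(F)(F)F`: 4.2
compound 3, `COc1cc2c(Nc3cnc(OCCCC4CCCC4)nc3)ncnc2cc1OCCCN1CCCCC1`: 4.5

Of the compounds shown here, three have been measured in a physicochemical assay for lipophilicity, at pH 7.4; on this read-out higher numbers stand for higher lipophilicity and lower numbers for lower lipophilicity. Compound 2 gives 4.2. Compound 3 gives 4.5, and this value and that of compound 2 lie within the usual scatter of each other, so the two cannot be told apart on this read-out. Compound 1 gives 3.2, which is lower than compound 2 by more than the scatter.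

Compound 4, `CNC(=O)c1sc(N2CC3CC2(CNC(=O)c2c[nH]c4ncccc24)C3)nc1C(F)(F)F`, has not yet been measured. It differs from compound 2 in one place: hydrogen in place of trifluoromethyl on an aromatic carbon. No pair of measured compounds differs in a single place, so the size of this kind of step is not shown directly by the numbers at hand. Removing a trifluoromethyl group and leaving a hydrogen in its place is, in general, expected to lower a value in this assay by a clear margin, beyond the scatter. The step from compound 2 to compound 4 is therefore estimated at a number 0.90 log units lower from compound 2 to compound 4 (beyond the scatter). For compound 4, the expected value is 3.3, with a likely range from 2.8 to 3.8.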

Compound 4, distribution coefficient: 3.1
The estimate for compound 4 lay 0.20 log units above the measured number, within the range that was stated.
By their numbers in this assay, from the lowest: compounds 4 and 1 (each within the scatter of the next); then compounds 2 and 3 (each within the scatter of the next).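

In this assay, going by these compounds alone, placing hydrogen where trifluoromethyl stood on an aromatic carbon of the six-membered aromatic ring with 1 nitrogen gives a number 1.10 log units lower from compound 2 to compound 4 (beyond the scatter) and is the first single-place step available in this set. The rest of the molecule stays the same, including the second trifluoromethyl group, so this one position alone is enough to move the number by more than the scatter. No separate measurement bears on why the step has this size.

From the compounds shown here alone, whether a chlorine atom or a nitrile on the same aromatic carbon would land nearer to compound 2 or to compound 4 remains open. Also open, going by these compounds, is whether replacing the second trifluoromethyl group with hydrogen would produce a step of similar size.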